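The compounds below may be only part of what the source reports. "The series", "measured", "known", "first", "only" and "open" are said of these compounds alone.

Measured so far in an ADME assay on microsomes from liver (Mus musculus) for metabolic stability, read by LC-MS, using NADPH, with stated times of 10 min and 30 min; on this read-out lower numbers stand for slow clearance and higher numbers for fast clearance:

- Compound 1 `CCC(=O)N[C@@H]1CCCc2c1cncc2N1C(=O)c2ccc(Cl)cc2[C@@H]1C` gives < 20.2 mL/min/kg
- Compound 2 `CC[C@@H]1c2cc(Cl)ccc2C(=O)N1c1cncc2c1CCC[C@H]2NC(C)=O` gives < 20.2 mL/min/kg
- Compound 3 `CCC(=O)N[C@@H]1CCCc2c1cncc2N1C(=O)c2ccc(Cl)cc2[C@@H]1CC` gives < 20.2 mL/min/kg

Each of these values is a limit and not a number. Compound 3 stands at the limit of < 20.2 mL/min/kg in this assay, at which 3 of the 3 values shown sit, so the numbers do not rank it against compound 1 or compound 2.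

Compound 4 `CCC(=O)N[C@@H]1CCCc2c1cncc2N1C(=O)c2ccc(Cl)cc2[C@H]1CC` differs from compound 3 in one way: the two compounds have the same atoms and bonds and differ only in configuration as drawn: 1 of 2 stereo elements differ; a stereocentre at a saturated ring carbon is drawn S in compound 3 and R in compound 4. Going by the values given here, the only measured step, a step that the two limits leave unreadable from compound 1 to compound 3, involves a methyl in place of a hydrogen rather than a change of configuration. Among the compounds with values here, it gives no size to carry over, and no measured pair here differs in configuration alone. On this thin evidence, no change beyond the usual scatter is expected in this assay, and the expected step is a step that the limit leaves unreadable from compound 3 to compound 4. For compound 4 the estimate is 20 mL/min/kg, with an expected range from 14 mL/min/kg to 42 mL/min/kg. A reading that again gives only a limit would be no surprise.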

Compound 4, clearance: 44.9 mL/min/kg
The estimate for compound 4 lay 2.2-fold (0.35 log units) below the measured number; measured number above the stated range.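

In this assay, changing the stereocentre at a saturated ring carbon from S to R gives an at least 2.2-fold higher number from compound 3 to compound 4 (0.34 log units; beyond the scatter), and this step can be tied to that stereocentre alone because of one fact: the fact that compounds 3 and 4 differ only in the configuration as drawn. With that R centre drawn in compound 4, methyl in place of hydrogen on a saturated chain carbon bound to a carbonyl carbon goes with an at least 2.2-fold higher number from compound 2 to compound 4 (0.34 log units; beyond the scatter), so the amide side also has a readable step. Compound 4 is the only one shown with a number rather than a limit, and the others all sit at one point: the limit of < 20.2 mL/min/kg in this assay, at which 3 of the 4 values shown sit.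

Going by these compounds, the full size of both steps remains open, since they start from a limit. Also open, on these data alone, is whether a longer chain, an amine or a carboxylic acid would keep or change the difference between the two configurations.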